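The compounds below may be only part of what the source reports. "The series", "measured", "known", "first", "only" and "open" are said of these compounds alone.

In a functional assay on HeLa cells (Homo sapiens) for inhibition (a lower number here means a stronger inhibitor, a higher number a weaker inhibitor), compound 1 `Cc1cn(/C=C/C=O)c(=O)[nH]c1=O` gives 23000 nM. Compound 2 `Cc1cn(/C=C/C#N)c(=O)[nH]c1=O` gives only a limit of the assay, > 100000 nM. Compound 3 `CC(=O)/C=C/n1cc(C)c(=O)[nH]c1=O` differs from compound 2 by acetyl in place of cyano on a double-bonded chain carbon bound to a double-bonded chain carbon, with acetyl in place of cyano on a double-bonded chain carbon bound to a double-bonded chain carbon. For the measured compounds named here, one measured step bears on this change: an at least 4.3-fold higher number from compound 1 to compound 2 (0.63 log units; beyond the scatter), where cyano replaced formyl. Since acetyl, like formyl, is a carbonyl group, a step of similar size in the opposite direction is expected, toward a lower number in this assay. The expected step is an at least 2.2-fold lower number from compound 2 to compound 3 (0.34 log units; beyond the scatter). For compound 3 the estimated value is 45000 nM, with an expected range of 15000 nM to 100000 nM.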

Compound 3, half-maximal inhibitory concentration: > 100000 nM
Compound 3: only a limit was reported; the forecaster's own chance of this, stated with the estimate: 35%; middle value at least 2.2-fold (0.34 log units) away from the limit.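

Methyl in place of hydrogen on a carbonyl carbon gives a clear loss (an at least 4.3-fold higher number from compound 1 to compound 3 (0.63 log units; beyond the scatter)) in this assay and so shows that this position is sensitive to a small change within the carbonyl series. A carbonyl on the chain is therefore not enough in itself, as acetyl fails to match formyl here. The step between the acetyl and cyano compounds cannot be read: the limit of > 100000 nM in this assay, at which 2 of the 3 values shown sit.

Still open, from the compounds shown here alone, is whether an amine, a carboxylic acid or a longer chain at this place would bring the number back down.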